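The compounds below may be only part of what the source reports. "The series", "measured", "known", "first", "only" and "open" are said of these compounds alone.

Measured so far:
- compound 1, `COc1cc2ncnc(Oc3ccc(NC(=O)Nc4ccc(Cl)c(C(F)(F)F)c4)c4cccnc34)c2cc1OC`: "not determined" (no result reported) in a functional assay on HUVEC cells (Homo sapiens) for inhibition, read by CellTiter-Glo, with a stated time of 72 h; on this read-out lower numbers stand for stronger inhibition and higher numbers for weaker inhibition
- compound 2, `COc1cc2ncnc(Oc3ccc(NC(=O)Nc4cnn(C(C)C)c4)c4ccccc34)c2cc1OC`: 630 nM in this assay
- compound 3, `COc1cc2ncnc(Oc3ccc(NC(=O)Nc4cc(C)on4)c4ccccc34)c2cc1OC`: "not determined" (no result reported) in this assay

Only compound 2 carries a number in this assay; compound 1 and compound 3 are without one, so compound 2 stands alone and nothing can be ranked against it. The compound not yet tested, compound 4 `COc1cc2ncnc(Oc3ccc(NC(=O)NC4(C#N)CCCC4)c4ccccc34)c2cc1OC`, shares the whole core with compound 2 and differs at one end of the urea: 1-cyanocyclopentyl in place of 1-isopropyl-1H-pyrazol-4-yl on an amide-type nitrogen. The group that leaves has one five-membered aromatic ring with 2 hetero atoms; the group that enters has one five-membered non-aromatic ring of carbon only with 1 triple bond outside aromatic rings, and it sits on an amide-type nitrogen whose other neighbours are: carbonyl carbon. Among the compounds with values here, no step between two measured compounds is available, so the size of this move cannot be read from a neighbouring pair. In this assay the expected step is a 3.2-fold higher number from compound 2 to compound 4 (0.50 log units; beyond the scatter), toward weaker inhibition and beyond the usual scatter. Compound 4 is therefore estimated at 2000 nM, with a plausible range from 500 nM to 8000 nM. The measured value decides.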

Compound 4, half-maximal inhibitory concentration: 3620 nM
Estimate against measurement, compound 4: 1.8-fold (0.26 log units) below; the range from low to high includes it.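

With compound 4, this end of the urea gains its first comparison: in this assay, putting 1-cyanocyclopentyl in place of 1-isopropyl-1H-pyrazol-4-yl gives a 5.7-fold higher number from compound 2 to compound 4 (0.76 log units; beyond the scatter), a change beyond the usual scatter and toward weaker inhibition. The group on this amide-type nitrogen therefore matters, yet an aromatic ring is not required for activity, as a five-membered ring of carbon only, carrying a nitrile, still leaves compound 4 with a measurable value of 3620 nM in this assay. The loss of the aromatic ring and the arrival of the nitrile come together in this single step, and no measurement at hand separates the two or explains the result.

What the compounds shown leave open is which of those two parts of the change accounts for the step, and a plain cyclopentyl group, without the nitrile, would be the natural point of comparison. Also open, from the compounds shown here alone, is how a smaller group on the pyrazole, such as methyl in place of isopropyl, would read in this assay.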